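Hydroxy for Chloro on the Sulfonamide Aryl

This account rests on a few compounds, and the source may have more. Where it says the series, first, only, none or still open, it means among the compounds named here.

Three compounds share one core and differ only in the aryl on the sulfonamide nitrogen. In an ADME assay on the whole organism for pharmacokinetics, with Homo sapiens as the target (a lower number here means that a smaller share of the oral dose reaches the circulation, a higher number that a larger share of the oral dose reaches the circulation), compound 1 `O=[N+]([O-])c1cccc(NS(=O)(=O)c2ccc3nc(-c4ccccc4)c(-c4ccccc4)nc3c2)c1` gives 85.6%, compound 2 `O=C(O)c1ccccc1NS(=O)(=O)c1ccc2nc(-c3ccccc3)c(-c3ccccc3)nc2c1` gives 83.6%, and compound 3 `O=S(=O)(Nc1ccc(Cl)cc1)c1ccc2nc(-c3ccccc3)c(-c3ccccc3)nc2c1` gives 100%. Compound 3 stands highest of the three: the step of a number 14.4 percentage points higher from compound 1 to compound 3 (beyond the scatter) and the step of a number 16.4 percentage points higher from compound 2 to compound 3 (beyond the scatter) both lie beyond the scatter, whereas a number 2 percentage points lower from compound 1 to compound 2 (within the scatter) does not. Compound 4 `O=S(=O)(Nc1ccc(O)cc1)c1ccc2nc(-c3ccccc3)c(-c3ccccc3)nc2c1` is the next member, and it differs from compound 3 by hydroxy in place of chloro on an aromatic carbon. The two steps that bear on this change, from compound 1 and from compound 2 up to compound 3, were modest, showing that exchanging the group on this phenyl ring shifts the read-out by a modest amount, and compound 3 already sits at the top of the measured numbers. A modest downward step in this assay is therefore expected, a number 16 percentage points lower from compound 3 to compound 4 (beyond the scatter), although a step within the scatter cannot be excluded. For compound 4 the estimated value in this assay is 84%, with a range from 62% to 100%.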

Compound 4, oral bioavailability: 93.9%
Estimate against measurement, compound 4: 9.9 percentage points below; the measured number falls inside the stated range.
By their numbers in this assay, from the lowest: compounds 2, 1, 4 and 3 (each within the scatter of the next, the first and the last beyond it).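

Hydroxy in place of chloro, on an aromatic carbon para to a large group, gives a step that cannot be told from the scatter: in this assay there is a number 6.1 percentage points lower from compound 3 to compound 4 (within the scatter), even though hydroxy brings the hydrogen-bond donor and acceptor that chloro lacks. The 4-hydroxyphenyl group also keeps a clear gap to the 2-carboxyphenyl group, with a number 10.3 percentage points higher from compound 2 to compound 4 (beyond the scatter), but it does not separate from the 3-nitrophenyl group, with a number 8.3 percentage points higher from compound 1 to compound 4 (within the scatter), whereas the 4-chlorophenyl group did.

From the compounds shown here alone, it remains open whether an amine, a methoxy group or a carboxylic acid at this same place would stay level with chloro and hydroxy. The compounds shown also leave open what a hydroxy group would give elsewhere on this ring. Nothing among the data shown explains these results.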